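The source may report more compounds than this note shows. Statements on the series, on what has been measured and on what is new or still open speak of the compounds shown alone.

Measured compounds:
compound 1 `COc1cc(/C=N/Cc2cccnc2)ccc1O` 30 mg/kg
compound 2 `Clc1ccccc1/C=N/Cc1cccnc1` 30 mg/kg
compound 3 `C/C(=N\Cc1cccnc1)c1ccccc1` 30 mg/kg

In a functional assay on the whole organism (strain Swiss albino) with Mus musculus as the target, in the maximal electroshock model, with a stated time of 4 h (on this read-out higher numbers stand for an effect only at larger amounts of compound and lower numbers for an effect already at smaller amounts), compound 3 stands level with compound 1 and compound 2 at the digits recorded; the nearest is compound 1 and the furthest compound 2, both within the scatter, so no order among the three can be read. Compound 4 `C/C(=N\Cc1cccnc1)c1cccc(N)c1` is not yet measured in this assay. It differs from compound 3 as follows: amino in place of hydrogen on an aromatic carbon. Within the data shown here, no pair of measured compounds shows a step for this change, so nothing points in either direction; the step from compound 3 to compound 4 is expected to be none beyond the scatter, no change at the digits printed from compound 3 to compound 4 (within the scatter). Compound 4 is therefore estimated at 30 mg/kg, with a range of 10 mg/kg to 100 mg/kg.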

Compound 4, minimum effective dose: 30 mg/kg
The estimate for compound 4 equals the measured number at the digits printed; the measured number falls inside the stated range.
By their numbers in this assay, from the lowest: compounds 1, 2, 3 and 4 (each within the scatter of the next).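

In this assay, among these compounds, amino in place of hydrogen on an aromatic carbon, meta to a large group, gives no change at the digits printed from compound 3 to compound 4 (within the scatter) as the only single-place step. Among the compounds shown here, the minimum effective dose therefore does not register this addition at this position, which the earlier compounds, with no single-place step among them, could not show. No supporting measurement accompanies this result. Open, going by these compounds, is whether a carboxylic acid, a methoxy group or a longer chain at this position would shift the dose, and whether amino elsewhere on the ring would.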